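Chain length at the hydroxamate end: compound 3 to compound 4

This account rests on a few compounds, and the source may have more. Where it says the series, first, only, none or still open, it means among the compounds named here.

Compound 3 `O=C(CCCCCCCN(Cc1ccc(F)cc1)c1ncc(C(=O)NCCCn2ccnc2)s1)NO` carries a hydroxamate on the longer of the two chains measured so far. In a functional assay on A549 cells (Homo sapiens) for inhibition, read by MTT assay, with a stated time of 72 h (a higher number here means a weaker inhibitor, a lower number a stronger inhibitor), compound 3 gives 6600 nM. Among the three numbers this is the lowest, yet it sits within the scatter of both neighbours: compound 1 `O=C(CCCCCCN(Cc1ccc(F)cc1)c1ncc(C(=O)NCCCn2ccnc2)s1)NO` gives 9700 nM, and compound 2 `CC(C)CCN(CCCCCC(=O)NO)c1ncc(C(=O)NCCCn2ccnc2)s1` gives 13000 nM, so no order among the three is established. Within the data shown here, the only step between two measured compounds that differ in one place is a 1.5-fold lower number from compound 1 to compound 3 (0.17 log units; within the scatter), a one-carbon lengthening of the chain that left the number unchanged beyond the scatter.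

Compound 4 `O=C(CCCCCN(Cc1ccc(F)cc1)c1ncc(C(=O)NCCCn2ccnc2)s1)NO` goes the other way, with a shorter chain. The change is hydroxycarbamoyl in place of 2-(hydroxycarbamoyl)ethyl on a saturated chain carbon, five bonds along the chain from a nitrogen on an aromatic ring. This removes two chain carbons rather than adding one, so the measured step covers only part of it; the direction of a 1.5-fold lower number from compound 1 to compound 3 (0.17 log units; within the scatter) would suggest that shortening should, if anything, raise the number, but that step itself was within the scatter.

For compound 4 the expectation is a small rise at most, with the estimate 11000 nM and a range of 4500 nM to 27000 nM, so that the expected step of a 1.7-fold higher number from compound 3 to compound 4 (0.22 log units; within the scatter) stays near the scatter.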

Compound 4, half-maximal inhibitory concentration: 54000 nM
Compound 4: middle estimate off by 4.9-fold (0.69 log units), on the low side; the whole stated range lies below it.
By their numbers in this assay, from the lowest: compounds 3, 1 and 2 (each within the scatter of the next); then compound 4.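

In this assay, among these compounds, shortening the chain to the hydroxycarbamoyl placement of compound 4 gives the first change that is beyond the scatter: an 8.2-fold higher number from compound 3 to compound 4 (0.91 log units; beyond the scatter) and a 5.6-fold higher number from compound 1 to compound 4 (0.75 log units; beyond the scatter), whereas the smaller chain step, a 1.5-fold lower number from compound 1 to compound 3 (0.17 log units; within the scatter), stayed within it. Among the compounds carrying 4-fluorophenyl, the number therefore separates only at the shortest chain shown, while the two longer chains remain unresolved from each other. At this shortest chain, the group on the saturated chain carbon bound to a nitrogen on an aromatic ring also counts, with 4-fluorophenyl in place of isobutyl giving a 4.2-fold higher number from compound 2 to compound 4 (0.62 log units; beyond the scatter).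

Nothing at hand speaks to what lies behind these steps.

On these data alone, it remains open how a longer chain, or a carboxylic acid in place of the hydroxamate at the chain end, would read in this assay. Also open, as far as these compounds go, is whether 4-fluorophenyl in place of isobutyl gives a step of the same size on the longer chains as on the chain shared by compound 2 and compound 4.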